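Swapping the Aromatic Tail of a Glutamate Receptor Ligand

The compounds below may be only part of what the source reports. "The series", "measured", "known", "first", "only" and "open" are said of these compounds alone.

Compound 1, whose structure is `N[C@]1(C(=O)O)[C@H]2[C@@H](C[C@H]1OCCCc1ccccc1)[C@]2(F)C(=O)O`, was tested in an assay on CHO cells for binding affinity to metabotropic glutamate receptor 2 (Rattus norvegicus) (on this read-out higher numbers stand for weaker inhibition and lower numbers for stronger inhibition), where compound 1 gives 9.83 nM. Two relatives share the same core and differ only in the group attached through the ether oxygen. Compound 2, with structure `N[C@]1(C(=O)O)[C@H]2[C@@H](C[C@H]1OCc1ccc(-c3ccccc3)cc1)[C@]2(F)C(=O)O`, gives 25.6 nM in this assay, and compound 3, with structure `N[C@]1(C(=O)O)[C@H]2[C@@H](C[C@H]1OC(c1ccccc1)c1ccccc1)[C@]2(F)C(=O)O`, gives 2.58 nM. Among these three numbers compound 1 stands second highest: compound 2 sits beyond the usual scatter above it, and compound 3 sits beyond the scatter below it, so the choice of aromatic tail clearly moves the read-out in both directions.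

Compound 4, with structure `N[C@]1(C(=O)O)[C@H]2[C@@H](C[C@H]1OCc1cccs1)[C@]2(F)C(=O)O`, has not yet been measured in this assay. Compared with compound 1 the change is thiophen-2-yl in place of phenethyl on a saturated chain carbon bound to an oxygen on a saturated carbon. For the measured compounds named here, no pair of measured compounds shows exactly this kind of swap, so the size of its effect is unknown from the data at hand. The tail of compound 4 is the shortest of the four, and the two bulkier tails give the two strongest numbers, so a modest step toward weaker inhibition is expected, estimated as a 2.5-fold higher number from compound 1 to compound 4 (0.41 log units; beyond the scatter). Compound 4 is therefore expected to give about 25 nM in this assay, within a range of 8 nM to 80 nM.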

Compound 4, inhibition constant: 8.79 nM
Compound 4: middle estimate off by 2.8-fold (0.45 log units), on the high side; low and high end bracket the measured number.
By their numbers in this assay, from the lowest: compound 3; then compounds 4 and 1 (each within the scatter of the next); then compound 2.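

In this assay, thiophen-2-yl in place of phenethyl gives a 1.1-fold lower number from compound 1 to compound 4 (0.05 log units; within the scatter), so the two tails cannot be told apart on this read-out. This shows that, on a saturated chain carbon bound to an oxygen on a saturated carbon, a tail with 5 heavy atoms in place of 8, a five-membered aromatic ring with a sulfur in place of a six-membered ring of carbon only, and a hydrogen-bond acceptor where there was none can all come together with no change beyond the scatter. No measured information is at hand that would explain this result.

The swap alters the ring and the tail's size in one step, so the compounds shown leave open whether each of these changes has no effect alone or whether separate effects happen to cancel. Phenyl or furan-2-yl in the place of thiophen-2-yl would begin to separate them: phenyl would keep the six-membered ring of carbon only, while furan-2-yl would keep the five-membered ring but put an oxygen where the sulfur stands.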